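The source may report more compounds than this note shows. Statements on the series, on what has been measured and on what is new or still open speak of the compounds shown alone.

Measured compounds:
- compound 1 `O=C1O[C@H]([C@@H](O)Cn2cc(-c3cc(C(F)(F)F)cc(C(F)(F)F)c3)nn2)C(OCc2ccccc2)=C1OCc1ccccc1`: in a functional assay on HCT-116 cells (Homo sapiens) for antiproliferative activity, read by MTT assay, with a stated time of 72 h (a lower number here means a stronger inhibitor, a higher number a weaker inhibitor), compound 1 gives 57200 nM
- compound 2 `O=C1O/C(=C\Cn2cc(-c3cc(F)cc(F)c3)nn2)C(OCc2ccccc2)=C1OCc1ccccc1`: compound 2 reaches only a limit, > 100000 nM
- compound 3 `CCCCc1cn(C[C@H](O)[C@H]2OC(=O)C(OCc3ccccc3)=C2OCc2ccccc2)nn1`: compound 3 gives 10400 nM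

Compound 3 therefore has the lowest of the two actual numbers, with compound 1 higher by a gap beyond the usual scatter. Compound 2 sits at the limit of > 100000 nM in this assay, at which 1 of the 3 values shown sits.

Compound 4 `COc1ccccc1-c1cn(C[C@H](O)[C@H]2OC(=O)C(OCc3ccccc3)=C2OCc2ccccc2)nn1` differs from compound 3 by 2-methoxyphenyl in place of butyl on an aromatic carbon. For the measured compounds named here, the only other measured compound carrying a ring at that position, compound 1, gives 57200 nM, a weaker result than compound 3. On that basis a modest shift toward a weaker inhibitor is expected, a 1.9-fold higher number from compound 3 to compound 4 (0.28 log units; within the scatter). Compound 4 is estimated at 20000 nM, most likely between 5000 nM and 80000 nM.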

Compound 4, half-maximal inhibitory concentration: > 100000 nM
Compound 4 was reported as a limit (the forecaster's own chance of this, stated with the estimate: 10%); middle value at least 5.0-fold (0.69 log units) away from the limit.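

In this assay, putting 2-methoxyphenyl in place of butyl on this aromatic carbon gives an at least 9.6-fold higher number from compound 3 to compound 4 (0.98 log units; beyond the scatter). For the compounds shown here, this is the first single-change comparison at this position, and it favours the butyl chain clearly over this ring. The result for compound 4 is a limit of the assay, not a number: the limit of > 100000 nM in this assay, at which 2 of the 4 values shown sit.

The compounds shown leave open whether the ring itself or its methoxy group accounts for the step, which an unsubstituted phenyl could test. Going by these compounds, how a longer chain such as octyl, or a butyl chain ending in an amine, would compare with compound 3 also remains open.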